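Nitro in place of hydrogen: compound 1 to compound 4

A few compounds are considered here, and "the series" means these few. Any claim that something is new, unique, unknown or untested is made for them only; others in the source may bear on it.

Measured in an ADME assay on MRC5 cells (Homo sapiens) for cytotoxicity, read by neutral red uptake (on this read-out higher numbers stand for lower toxicity in this test and lower numbers for higher toxicity in this test), all three values being limits:
- compound 1 `O=c1[nH]c(SCc2ccccc2)nc2ccccc12`: > 64000 nM
- compound 2 `O=c1[nH]c(SCc2cccs2)nc2ccccc12`: > 64000 nM
- compound 3 `O=c1[nH]c(SCc2cccc([N+](=O)[O-])c2)nc2ccccc12`: > 64000 nM

Compound 1 has no number, only a limit of > 64000 nM. The series as a whole shows (the limit of > 64000 nM in this assay, at which 3 of the 3 values shown sit).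

Compound 4 `O=c1[nH]c(SCc2ccc([N+](=O)[O-])cc2)nc2ccccc12` has nitro in place of hydrogen on an aromatic carbon.

Going by the values given here, two measured steps bear on this change: a step that the two limits leave unreadable from compound 1 to compound 3, which makes the same kind of replacement, and less directly a step that the two limits leave unreadable from compound 1 to compound 2. Neither gives a size, so no step beyond the scatter is expected in this assay, and another limit is the likeliest reading. The expected change is a number no higher from compound 1 to compound 4 (the limit leaves the size open). For compound 4 the estimate is 64000 nM, with an expected range from 30000 nM to 128000 nM.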

Compound 4, half-maximal cytotoxic concentration: > 64000 nM
Compound 4 was reported as a limit (the forecaster's own chance of this, stated with the estimate: 80%); the middle value lies on the limit itself.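

No step can be read from compound 1 to compound 4, as both values are limits. The compounds shown leave open whether nitro in place of hydrogen changes the read-out at all, since every value sits at one limit: the limit of > 64000 nM in this assay, at which 4 of the 4 values shown sit.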